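A few compounds are considered here, and "the series" means these few. Any claim that something is new, unique, unknown or untested is made for them only; others in the source may bear on it.

Working notes on the series. Among the measured compounds shown here, in a physicochemical assay for solubility, read by LC-MS, in phosphate buffer, measured as kinetic solubility, with a stated time of 24 h, at 25 degrees C, at pH 7.4 (a lower number here means a less soluble compound, a higher number a more soluble compound), compound 1 `Nc1nccc(-c2cc(OC3COC3)c3c(N)n[nH]c3c2)n1` gives 383000 nM, the higher of the two numbers so far; compound 2 `Nc1nccc(-c2ccc3c(NCc4ccccc4)n[nH]c3c2)n1` gives 17000 nM in this assay, and the gap between them lies beyond the scatter. Compound 3 `Nc1nccc(-c2cc(OC3CCCOC3)c3c(N)n[nH]c3c2)n1` is not yet measured; it differs from compound 1 by oxan-3-yl in place of oxetan-3-yl on an oxygen on an aromatic ring. For the measured compounds named here, no measured pair shows this change, so the expected step of a 2.6-fold lower number from compound 1 to compound 3 (0.41 log units; beyond the scatter) is a guess of a small to moderate drop in this assay. Compound 3 is accordingly expected near 150000 nM, with a plausible range from 50000 nM to 400000 nM.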

Compound 3, solubility: 1000000 nM
Compound 3: middle estimate off by 6.7-fold (0.82 log units), on the low side; the whole stated range lies below it.
By their numbers in this assay, from the lowest: compound 2; then compound 1; then compound 3.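

In this assay the change on this oxygen from the four-membered oxetan-3-yl to the six-membered oxan-3-yl gives a 2.6-fold higher number from compound 1 to compound 3 (0.42 log units; beyond the scatter) and the number rises rather than falls. For this one pair, the position tolerates the larger ring with its single ring oxygen without any loss in this read-out. Nothing at hand accounts for the step. Still open, going by these compounds, is how an amine or a carboxylic acid on this oxygen, or a longer open chain in place of the ring, would read in this assay.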